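Methoxy Removal in a Growth Inhibition Series

The source may report more compounds than this note shows. Statements on the series, on what has been measured and on what is new or still open speak of the compounds shown alone.

Measured in a functional assay on NSCLC cells (Homo sapiens) for cytotoxicity, read by sulforhodamine B assay, with a stated time of 48 h; on this read-out lower numbers stand for stronger inhibition of growth and higher numbers for weaker inhibition of growth:
- compound 1 `COc1nc2sc(C)cn2c1C=C1C(=O)N(C)c2ccccc21`: 73200 nM
- compound 2 `O=C1Nc2ccccc2C1=Cc1c(-c2ccncc2)nc2sccn12`: 82400 nM
- compound 3 `COc1ccc2c(c1)/C(=C\c1c(OC)nc3sc(C)cn13)C(=O)N2`: 58700 nM

The three values lie within the usual scatter of one another, so compound 3 cannot be separated from compound 1 or compound 2. Compound 4 `COc1nc2sc(C)cn2c1/C=C1/C(=O)Nc2ccccc21` is compound 3 with hydrogen in place of methoxy on an aromatic carbon. Going by the values given here, no measured pair isolates this change, so the expectation rests on weak evidence. Compound 2 gives 82400 nM despite differing from compound 3 in more than one place, which suggests no step beyond the scatter in this assay. The expected change is a 1.1-fold higher number from compound 3 to compound 4 (0.04 log units; within the scatter). For compound 4, the estimated value is 65000 nM, with an expected range from 35000 nM to 100000 nM.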

Compound 4, concentration for total growth inhibition: 65200 nM
Beside the measured number, compound 4's estimate is 1.0-fold (0.00 log units) below it, and the stated range covers the measured number.
By their numbers in this assay, from the lowest: compounds 3, 4, 1 and 2 (each within the scatter of the next).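

Going by these compounds alone, compounds 3 and 4 form the first pair here that differ in one place, and this assay shows for hydrogen in place of methoxy on an aromatic carbon a 1.1-fold higher number from compound 3 to compound 4 (0.05 log units; within the scatter) in the growth read-out. At this position of the six-membered aromatic ring, methoxy and hydrogen therefore cannot be told apart on this read-out. Nothing available gives a reason for this result.

Only these two groups are compared at this position. An amine, a carboxylic acid or a longer chain there could give a different number.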